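The compounds below may be only part of what the source reports. "The series", "measured", "known", "first", "only" and "open" are said of these compounds alone.

Compound 2 `O=C1c2c[n+]([O-])c3ccccc3c2C(=O)c2c1c1ccccc1n2Cc1cn(C[C@@H](O)CO)nn1` is one of three close relatives measured in a functional assay on A549 cells (Homo sapiens) for cytotoxicity, read by MTT assay, with a stated time of 72 h (on this read-out lower numbers stand for stronger inhibition and higher numbers for weaker inhibition), and there compound 2 gives 390 nM. Its nearest neighbour is compound 1 `O=C1c2c[n+]([O-])c3ccccc3c2C(=O)c2c1c1ccccc1n2Cc1cn([C@H]2C[C@H](O)[C@@H](CO)O2)nn1`, which in this assay gives 350 nM; the step of a 1.1-fold higher number from compound 1 to compound 2 (0.05 log units; within the scatter) is within the scatter, so the two cannot be told apart. The furthest is compound 3 `O=C1c2c[n+]([O-])c3ccccc3c2C(=O)c2c1c1ccccc1n2Cc1cn([C@H]2O[C@H](CO)[C@@H](O)[C@H]2O)nn1`, which in this assay gives 2680 nM, a modest step of a 6.9-fold higher number from compound 2 to compound 3 (0.84 log units; beyond the scatter) and likewise a 7.7-fold higher number from compound 1 to compound 3 (0.88 log units; beyond the scatter).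

The unmeasured compound 4 `O=C1c2c[n+]([O-])c3ccccc3c2C(=O)c2c1c1ccccc1n2CCCCN1CCCCC1` differs from compound 2 in one place: 3-(piperidin-1-yl)propyl in place of 1-(2,3-dihydroxypropyl)-1H-1,2,3-triazol-4-yl on a saturated chain carbon bound to an aromatic nitrogen. Among the measured compounds shown here, every measured step so far changed only the group on the triazole nitrogen and kept the triazole itself; none of them removes the triazole or introduces a piperidine, so no measured step bears directly on this change. With no guide from the data, the step of a 1.3-fold lower number from compound 2 to compound 4 (0.11 log units; within the scatter) is expected to stay close to compound 2, with a wide margin either way. Compound 4 in this assay is therefore estimated at 300 nM, with a range from 60 nM to 1500 nM.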

Compound 4, half-maximal inhibitory concentration: 150 nM
Compound 4: the middle estimate sits 2.0-fold (0.30 log units) above what was measured; the measured number falls inside the stated range.
By their numbers in this assay, from the lowest: compound 4; then compounds 1 and 2 (each within the scatter of the next); then compound 3.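

Until now only the group on the triazole nitrogen had varied, whereas this change replaces the triazole and its diol altogether. In this assay the step is a 2.6-fold lower number from compound 2 to compound 4 (0.41 log units; beyond the scatter) and it goes toward stronger inhibition, so on a saturated chain carbon bound to an aromatic nitrogen the triazole is not needed for cytotoxicity in this compound series, and neither are the hydroxyl groups. Nothing shown explains why the number falls.

The swap removes the triazole, removes the diol and brings in a piperidine all at once, so the compounds shown cannot say which of these parts accounts for the step. A plain pentyl chain, or a morpholine at the end of the butyl chain, would help to separate these parts.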